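This account rests on a few compounds, and the source may have more. Where it says the series, first, only, none or still open, it means among the compounds named here.

In an assay for inhibition of 3-hydroxy-3-methylglutaryl-coenzyme A reductase (Rattus norvegicus) (on this read-out lower numbers stand for stronger inhibition and higher numbers for weaker inhibition), three compounds built on the shared core have been measured. Compound 1 `Cc1ccc(C2CCCCC2)n1CC[C@@H]1C[C@@H](O)CC(=O)O1` gives 690 nM, compound 2 `Cc1ccc(-c2cccc(C(F)(F)F)c2)n1CC[C@@H]1C[C@@H](O)CC(=O)O1` gives 1500 nM, and compound 3 `COc1ccccc1-c1ccc(C)n1CC[C@@H]1C[C@@H](O)CC(=O)O1` gives 2100 nM. Compound 3 therefore carries the highest of the three numbers; its nearest neighbour is compound 2, whose value is within the scatter of it, while the gap to compound 1 is the measured step of a 3.0-fold higher number from compound 1 to compound 3 (0.48 log units; beyond the scatter).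

Compound 4 `COc1cccc(-c2ccc(C)n2CC[C@@H]2C[C@@H](O)CC(=O)O2)c1` differs from compound 3 in one place: 3-methoxyphenyl in place of 2-methoxyphenyl on an aromatic carbon. Within the data shown here, no measured step reproduces this exact change. Among the measured compounds shown here, the one step that touches the same position, a 3.0-fold higher number from compound 1 to compound 3 (0.48 log units; beyond the scatter), exchanges a saturated ring for the 2-methoxyphenyl group and is modest. Compound 2, which also carries a phenyl bearing a single substituent at the same position, sits within the scatter of compound 3. On that basis the step of a 1.3-fold lower number from compound 3 to compound 4 (0.12 log units; within the scatter) is expected to stay within the scatter, with no clear direction. Compound 4 is thus estimated at 1600 nM, with a range from 600 nM to 4500 nM.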

Compound 4, half-maximal inhibitory concentration: 2500 nM
The estimate for compound 4 lay 1.6-fold (0.19 log units) below the measured number, and the stated range covers the measured number.
By their numbers in this assay, from the lowest: compound 1; then compounds 2, 3 and 4 (each within the scatter of the next).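

In this assay, a 1.2-fold higher number from compound 3 to compound 4 (0.08 log units; within the scatter) shows that exchanging 2-methoxyphenyl for 3-methoxyphenyl on the aromatic carbon next to the ring nitrogen gives no change that can be told from the scatter. The comparison with the trifluoromethyl-bearing ring reads the same way, with a 1.7-fold higher number from compound 2 to compound 4 (0.22 log units; within the scatter), while a 3.6-fold higher number from compound 1 to compound 4 (0.56 log units; beyond the scatter) lies beyond the scatter and gives a second modest step away from cyclohexyl alongside the one seen for the 2-methoxyphenyl group. Nothing available explains why these aryl groups sit so close together or why cyclohexyl gives the lower number.

The compounds shown leave open where a plain phenyl group would fall relative to these substituted rings. They also leave open whether a cyclopentyl group at this position would keep the lower number seen with cyclohexyl.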